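From 2-methylphenyl to naphthalen-2-yl on the shared core

A few compounds are considered here, and "the series" means these few. Any claim that something is new, unique, unknown or untested is made for them only; others in the source may bear on it.

Compound 1 `Cc1cc(C)cc(CN2CCc3ncn(COCc4ccccc4)c3/C(=C/c3ccccc3)C2=O)c1`: 40900 nM
Compound 2 `Cc1ccccc1CN1CCc2ncn(COCc3ccccc3)c2/C(=C/c2ccccc2)C1=O`: 53300 nM

In a functional assay on HepG2 cells (Homo sapiens) for inhibition, read by MTT assay, with a stated time of 72 h (a higher number here means a weaker inhibitor, a lower number a stronger inhibitor), compound 2 gives 53300 nM, which lies within the scatter of compound 1 at 40900 nM. Compound 3 `O=C1/C(=C\c2ccccc2)c2c(ncn2COCc2ccccc2)CCN1Cc1ccc2ccccc2c1` keeps the shared core but carries naphthalen-2-yl in place of 2-methylphenyl on a saturated chain carbon bound to an amide-type nitrogen in a ring. Among the compounds with values here, the only measured step at this place is a 1.3-fold higher number from compound 1 to compound 2 (0.12 log units; within the scatter). That single small step is a thin guide to the entering group, so no step beyond the scatter is expected in this assay. The estimated step is a 1.3-fold lower number from compound 2 to compound 3 (0.12 log units; within the scatter). The estimate for compound 3 is an expected 40000 nM, ranging from 18000 nM to 85000 nM.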

Compound 3, half-maximal inhibitory concentration: 23700 nM
For compound 3 the middle estimate is 1.7-fold (0.23 log units) above the measured one; the measured number falls inside the stated range.
By their numbers in this assay, from the lowest: compounds 3, 1 and 2 (each within the scatter of the next, the first and the last beyond it).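

In this assay this position shows its first step beyond the scatter: going to naphthalen-2-yl, with its two aromatic rings, gives a 2.2-fold lower number from compound 2 to compound 3 (0.35 log units; beyond the scatter) in a modest change. The same group gives a 1.7-fold lower number from compound 1 to compound 3 (0.24 log units; within the scatter) and stays within the scatter, so it stands clear of 2-methylphenyl only, not of 3,5-dimethylphenyl.

All three groups at this place are carbon only; a pyridine ring or a phenyl ring bearing a carboxylic acid or an amine remains an open case. No evidence here explains the size of these steps.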